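Removing the methoxy group from compound 3

The source may report more compounds than this note shows. Statements on the series, on what has been measured and on what is new or still open speak of the compounds shown alone.

Compound 1 `Oc1ccc(CNCc2ccc(C(F)(F)F)cc2)c2cccnc12` reaches only a limit in a functional assay on U-87MG ATCC cells (Homo sapiens) for antiproliferative activity, with a stated time of 3 days (a lower number here means that less compound is needed, a higher number that more compound is needed for the effect), > 10 uM. Among the compounds with values here, compound 2 `CC(C)(C)OC(=O)N(Cc1ccc(C(F)(F)F)cc1)Cc1ccc(O)c2ncccc12` gives 2 uM in this assay, the only true number so far. For compound 3 `COc1ccc(CN(Cc2ccc(C(F)(F)F)cc2)Cc2ccc(O)c3ncccc23)c2cccnc12` the entry reads "not determined" (no result reported), so this compound offers no number to start from.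

Compound 4 `Oc1ccc(CN(Cc2ccc(C(F)(F)F)cc2)Cc2cccc3ncccc23)c2cccnc12` follows from compound 3 by one change, hydrogen in place of methoxy on an aromatic carbon, which turns 8-methoxyquinolin-5-yl into quinolin-5-yl.

Within the data shown here, the only measured step is an at least 5.0-fold lower number from compound 1 to compound 2 (0.69 log units; beyond the scatter), tert-butoxycarbonyl in place of hydrogen on an amine nitrogen. It lies at a different place in the structure and does not size the methoxy change. No size or direction is therefore expected for the step itself in this assay.

Compound 4 can only be placed against the series as a whole. The nearest anchor is compound 2 at 2 uM, whose amine nitrogen, like that of compound 4, carries no hydrogen. From the compounds shown here alone, the upper side stays open, given (the limit of > 10 uM in this assay, at which 1 of the 3 values shown sits).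

For compound 4 the expected value is estimated at 3 uM, with an expected range of 0.8 uM to 10 uM.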

Compound 4, concentration for half-maximal effect: > 10 uM
Compound 4 gave a limit, no number (the forecaster's own chance of this, stated with the estimate: 20%); middle value at least 3.3-fold (0.52 log units) from the limit.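

Replacing tert-butoxycarbonyl with (quinolin-5-yl)methyl on the amine nitrogen gives an at least 5.0-fold higher number from compound 2 to compound 4 (0.69 log units; beyond the scatter) in this assay, so a nitrogen without hydrogen is not enough by itself for a true number. Compound 4 reaches only a limit, > 10 uM. Among the compounds shown, a true number appears only with tert-butoxycarbonyl on that nitrogen in compound 2, and compound 4 goes against any reading that simply adding a group there is enough, leaving more of the series at the limit: the limit of > 10 uM in this assay, at which 2 of the 4 values shown sit.

The step from compound 1 to compound 4 cannot be read, as both values are limits, and with no result for compound 3 the effect of replacing methoxy with hydrogen remains unsized. From the compounds shown here alone, it also remains open whether an acetyl or a plain methyl group on the amine nitrogen, in place of tert-butoxycarbonyl, would give a true number in this assay.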